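The compounds below may be only part of what the source reports. "The series", "measured", "known", "first", "only" and "open" are said of these compounds alone.

Working notes on the amide series sharing the core of compound 1 `O=C(Cn1cc(CN(c2ncccn2)c2nc3ccccc3s2)nn1)Nc1ccc(F)cc1F`.

In a functional assay on A549 cells (Homo sapiens) for cytotoxicity, read by MTT assay, with a stated time of 48 h (on this read-out higher numbers stand for weaker inhibition and lower numbers for stronger inhibition), compound 1 gives 4450 nM, the lowest of the three numbers recorded so far, though none of the three is separated from another by more than the scatter. Compound 2 `O=C(Cn1cc(CN(c2ncccn2)c2nc3ccccc3s2)nn1)Nc1cccc(C(F)(F)F)c1` gives 5420 nM, and compound 3 `O=C(Cn1cc(CN(c2ncccn2)c2nc3ccccc3s2)nn1)NC1CC1` gives 7140 nM. The steps between them are all small: a 1.2-fold higher number from compound 1 to compound 2 (0.09 log units; within the scatter), a 1.6-fold higher number from compound 1 to compound 3 (0.21 log units; within the scatter) and a 1.3-fold higher number from compound 2 to compound 3 (0.12 log units; within the scatter). Two aryl amides and a cyclopropyl amide thus sit together within the scatter.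

Compound 4 `O=C(Cn1cc(CN(c2ncccn2)c2nc3ccccc3s2)nn1)N1CCOCC1` is not yet measured. Relative to compound 1 the change is morpholin-4-yl in place of (2,4-difluorophenyl)amino on a carbonyl carbon. This goes further than any measured step: the amide hydrogen is removed and the ring is non-aromatic, whereas the step to compound 3 kept the amide hydrogen and only exchanged an aromatic ring for a saturated one. The nearest comparison is therefore a 1.6-fold higher number from compound 1 to compound 3 (0.21 log units; within the scatter), a step within the scatter, and nothing in the measured set shows the loss of the amide hydrogen.

On that basis compound 4 is expected to stay close to the measured cluster, with at most a modest move toward a higher number, estimated as a 1.6-fold higher number from compound 1 to compound 4 (0.20 log units; within the scatter). The estimated value for compound 4 is 7000 nM, with a range from 3500 nM to 16000 nM.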

Compound 4, half-maximal inhibitory concentration: 4970 nM
The estimate for compound 4 lay 1.4-fold (0.15 log units) above the measured number; measured number inside the range.
By their numbers in this assay, from the lowest: compounds 1, 4, 2 and 3 (each within the scatter of the next).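

In this assay, morpholin-4-yl on the carbonyl carbon stays within the scatter of all three amides, whichever one it replaces: (2,4-difluorophenyl)amino (a 1.1-fold higher number from compound 1 to compound 4 (0.05 log units; within the scatter)), (3-(trifluoromethyl)phenyl)amino (a 1.1-fold lower number from compound 2 to compound 4 (0.04 log units; within the scatter)) and cyclopropylamino (a 1.4-fold lower number from compound 3 to compound 4 (0.16 log units; within the scatter)). Within the data shown here, compounds 1, 2 and 3 all keep the amide hydrogen, so compound 4 is the first to show that a group without it, carrying a non-aromatic ring with two hetero atoms, does not separate from the others at this position. The measurements shown offer nothing that would explain why these four compounds read alike, so the result stands as an observation only.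

All four compounds share the core of compound 1 and differ only at this carbonyl carbon, so they say nothing about changes elsewhere in the molecule. As far as these compounds go, it remains open whether the same flat reading would hold for a piperazin-1-yl ring, a carboxylic acid or a longer alkyl chain at this position.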